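A few compounds are considered here, and "the series" means these few. Any claim that something is new, unique, unknown or untested is made for them only; others in the source may bear on it.

Compound 2 `O=c1[nH]cc(S(=O)(=O)Nc2ccc(-c3cn(-c4ccc(F)cc4)nn3)cc2)c(=O)[nH]1` is one of two sulfonamides of the shared core examined in an ADME assay on L02 cells (Homo sapiens) for cytotoxicity, read by MTT assay, with a stated time of 24 h; on this read-out higher numbers stand for lower toxicity in this test and lower numbers for higher toxicity in this test. In this assay compound 2 gives "not toxic" (no number reported), a result without a number. Compound 1 `O=c1[nH]cc(S(=O)(=O)Nc2ccc(-c3cn(-c4ccccc4F)nn3)cc2)c(=O)[nH]1` stands in this assay at > 100000 nM, a limit of the assay rather than a measured number. Compound 2 thus has no single number, and the only fixed point among the values shown is the limit of > 100000 nM in this assay, at which 1 of the 2 values shown sits. Compound 3 `O=c1[nH]cc(S(=O)(=O)Nc2ccc(-c3cn(-c4ccc(Cl)cc4)nn3)cc2)c(=O)[nH]1` differs from compound 2 by chloro in place of fluoro on an aromatic carbon, para to a large group. Within the data shown here, no step between measured compounds is available, so no shift beyond the usual scatter is expected from this exchange in this assay. Compound 3 is therefore expected to read about 100000 nM in this assay, with a likely range from 30000 nM to 300000 nM, and a reading that is again only a limit seems probable.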

Compound 3, half-maximal cytotoxic concentration: 42900 nM
Compound 3: middle estimate off by 2.3-fold (0.37 log units), on the high side; the range from low to high includes it.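

In this assay, among these compounds, the 4-fluorophenyl to 4-chlorophenyl change yields the first actual number at this position: compound 3 reads 42900 nM, while compound 2 carries only the result "not toxic" (no number reported), so the size of this exchange cannot be read. Having 4-chlorophenyl in place of 2-fluorophenyl on the aromatic nitrogen brings an at least 2.3-fold lower number from compound 1 to compound 3 (0.36 log units; beyond the scatter), which shows that the aryl group can shift this read-out beyond the usual scatter. That step starts from a limit, and it remains the only fixed reference point for compound 3 in this small set: the limit of > 100000 nM in this assay, at which 1 of the 3 values shown sits.

From the compounds shown here alone, it remains open how a bromo, methoxy or amino group would read at the same place on the ring. Going by these compounds, it is also open whether chloro would give a similar reading in the 2-position, where compound 1 carries its fluoro.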